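The source may hold more compounds than are shown below. What is called first, only, known or untested is meant among the compounds shown, and "the series" means these compounds.

Working notes on the aminothiophene ketone series.

Of the compounds shown here, three have been measured. Compound 1 `Nc1scc(-c2cc(C(F)(F)F)cc(C(F)(F)F)c2)c1C(=O)c1ccccc1` gives 93% in a functional assay on CHO cells for agonist activity at adenosine receptor A1 (Homo sapiens), read by fluorescence and ERK phosphorylation, with stated times of 30 min and 1.5 h, tested at 10 uM; on this read-out lower numbers stand for a weaker effect and higher numbers for a stronger effect at the one concentration tested. Compound 2 `Nc1scc(-c2cccc(C(F)(F)F)c2)c1C(=O)c1ccc(Cl)cc1` gives 73% in this assay, and compound 3 `Nc1scc(-c2cccc(Cl)c2)c1C(=O)c1ccc(Cl)cc1` gives 75% in this assay. On these numbers compound 2 stands lowest of the three: its nearest neighbour is compound 3, separated by a number 2 percentage points higher from compound 2 to compound 3 (within the scatter), while compound 1 lies well beyond the scatter above it.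

The next compound, compound 4 `Nc1scc(-c2cc(C(F)(F)F)cc(C(F)(F)F)c2)c1C(=O)c1ccc(Cl)cc1`, is compared with compound 2. The change is trifluoromethyl in place of hydrogen on an aromatic carbon, the new group sitting meta to the trifluoromethyl group already present on that six-membered aromatic ring of carbon only.

Among the compounds with values here, no measured step covers this exact change. Within the data shown here, the only single-place step in hand, chloro for trifluoromethyl on the same ring, was a number 2 percentage points higher from compound 2 to compound 3 (within the scatter), which says little about adding a second such group. Compound 1 and compound 2 differ in two places, yet compound 1 carries the same pair of trifluoromethyl groups that compound 4 will carry. Compound 1 gives 93%, and compound 2 gives 73%. On that basis a rise in this assay is expected, amounting to a number 13 percentage points higher from compound 2 to compound 4 (beyond the scatter). Compound 4 is therefore estimated at 86%, with a plausible range from 70% to 98%.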

Compound 4, a percentage reported as activity, at one concentration (the size of the read-out at that concentration, not a potency): 74%
For compound 4 the middle estimate is 12 percentage points above the measured one, within the range that was stated.
By their numbers in this assay, from the lowest: compounds 2, 4 and 3 (each within the scatter of the next); then compound 1.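

In this assay, trifluoromethyl in place of hydrogen, on an aromatic carbon meta to the trifluoromethyl group, gives a number 1 percentage points higher from compound 2 to compound 4 (within the scatter); with the chloro group present, this position therefore accepts a second trifluoromethyl group without a readable change in the read-out. With the pair of trifluoromethyl groups held constant, chloro in place of hydrogen on an aromatic carbon gives a number 19 percentage points lower from compound 1 to compound 4 (beyond the scatter), so the high number of compound 1 goes with the absence of chloro, not with the pair of trifluoromethyl groups alone. Nothing available explains either result.

The compounds shown leave open whether adding the second trifluoromethyl group is equally silent without the chloro group, since no pair here tests that change on a ring lacking chloro. They also leave open how this position responds to groups of a different kind, such as an amine, a carboxylic acid or a longer alkyl chain, and how any of these compounds compare in potency, as each number comes from a single concentration.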